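Sulfonyl Aryl Variation in a Serotonin Receptor Binding Series

The source may report more compounds than this note shows. Statements on the series, on what has been measured and on what is new or still open speak of the compounds shown alone.

compound 1: `COc1cc(N)c(Cl)cc1C(=O)CCC1CCN(CCNS(=O)(=O)c2ccc(C)cc2)CC1`, 18 nM
compound 2: `COc1ccc(S(=O)(=O)NCCN2CCC(CCC(=O)c3cc(Cl)c(N)cc3OC)CC2)cc1OC`, 8.2 nM

In an assay on brain for displacement of a labelled ligand from 5-hydroxytryptamine receptor 4 (Cavia porcellus), with a stated time of 30 min, in the presence of a further agent that is not named here (a lower number here means a stronger inhibitor, a higher number a weaker inhibitor), compound 1 gives 18 nM and compound 2 gives 8.2 nM, the lowest of the two numbers. Among the compounds with values here, the single measured step is a 2.2-fold lower number from compound 1 to compound 2 (0.34 log units; beyond the scatter), a modest move upon exchanging the aryl on the sulfonyl sulfur. Compound 3, `COc1cc(N)c(Cl)cc1C(=O)CCC1CCN(CCNS(=O)(=O)c2ccc(N)c(Br)c2)CC1`, carries 4-amino-3-bromophenyl in place of 3,4-dimethoxyphenyl on a sulfonyl sulfur. Within the data shown here, that same position is the one the measured step probed, but no measured compound bears an amino or bromine on this ring, so the guide is indirect. Compound 3 is expected at 12 nM, within 4 nM to 40 nM. The expected step is a 1.5-fold higher number from compound 2 to compound 3 (0.17 log units; within the scatter), which is not beyond the scatter.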

Compound 3, inhibition constant: 5.3 nM
The estimate for compound 3 lay 2.3-fold (0.35 log units) above the measured number; the range from low to high includes it.
By their numbers in this assay, from the lowest: compounds 3 and 2 (each within the scatter of the next); then compound 1.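

In this assay, a sulfonyl aryl bearing an amino group and a bromine holds up as well as one bearing two methoxy groups: 4-amino-3-bromophenyl in place of 3,4-dimethoxyphenyl gives a 1.5-fold lower number from compound 2 to compound 3 (0.19 log units; within the scatter). Against 4-methylphenyl, the same group gives a 3.4-fold lower number from compound 1 to compound 3 (0.53 log units; beyond the scatter), so two differently substituted aryl groups on the sulfonyl sulfur now stand apart from 4-methylphenyl, and no compound shown goes against this. On these data alone, whether 4-aminophenyl or 3-bromophenyl alone would give the same step remains open, as does the effect of a carboxylic acid on this ring. Nothing measured here explains the differences among these aryl groups.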